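This account rests on a few compounds, and the source may have more. Where it says the series, first, only, none or still open, it means among the compounds named here.

Compound 1 `[O-][S+](Cc1ccccc1)c1nnc(-c2ccncc2)o1`: 4000 nM in a functional assay on HUVEC cells (Homo sapiens) for inhibition, read by ELISA; a lower number here means a stronger inhibitor, a higher number a weaker inhibitor
Compound 2 `[O-][S+](Cc1ccccc1)c1nnc(-c2cccs2)o1`: 7000 nM in this assay
Compound 3 `COc1c(C)cnc(C[S+]([O-])c2nnc(-c3cccn3C)o2)c1C`: 6000 nM in this assay

Compound 2 has the highest of the three numbers in this assay, but its gaps to compound 3 and to compound 1 both lie within the usual scatter of repeated measurements, so the three compounds cannot be told apart on these figures. The step to compound 4 `[O-][S+](Cc1ccccc1)c1nnc(-c2ccccc2O)o1` changes one group on the shared core: 2-hydroxyphenyl in place of thiophen-2-yl on an aromatic carbon. Going by the values given here, the only measured step that touches this position is a 1.8-fold higher number from compound 1 to compound 2 (0.24 log units; within the scatter), and it stayed within the scatter. Compound 3, which carries yet another ring at this position together with a different group on the sulfur-bearing side, also sits close to compounds 1 and 2. Across three different rings at this position the numbers have hardly moved, so no step beyond the scatter is expected for compound 4, in either direction. The expected step is a 1.4-fold lower number from compound 2 to compound 4 (0.15 log units; within the scatter). Compound 4 is estimated at 5000 nM, within a range from 1500 nM to 15000 nM.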

Compound 4, half-maximal inhibitory concentration: 8000 nM
For compound 4 the middle estimate is 1.6-fold (0.20 log units) below the measured one; the range from low to high includes it.
By their numbers in this assay, from the lowest: compounds 1, 3, 2 and 4 (each within the scatter of the next).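

Putting 2-hydroxyphenyl in place of thiophen-2-yl adds a hydrogen-bond donor and a larger ring, yet in this assay it gives a 1.1-fold higher number from compound 2 to compound 4 (0.06 log units; within the scatter) and the number stays put. Against pyridin-4-yl the change gives a 2.0-fold higher number from compound 1 to compound 4 (0.30 log units; within the scatter), which is also no measurable shift, so on this core the position has now taken a carbon-only six-membered ring carrying a hydroxyl without a step beyond the scatter. Nothing available accounts for this flat result.

All the groups shown at this position are aromatic rings, so it remains open whether an amine, a carboxylic acid or a longer alkyl chain there would move the number beyond the scatter. Plain phenyl at this position would show separately what the hydroxyl contributes.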